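Replacing an ethyl group with a chlorine on the anilide ring

The source may report more compounds than this note shows. Statements on the series, on what has been measured and on what is new or still open speak of the compounds shown alone.

Three compounds share one core, a sulfonamide carrying a different aryl group on its nitrogen. Compound 1 `CCc1ccccc1NS(=O)(=O)c1ccc(N2CCNC2=O)cc1` gives 350 nM in a functional assay on MCF7 cells (Homo sapiens) for antiproliferative activity, read by sulforhodamine B assay, with a stated time of 48 h (a higher number here means a weaker inhibitor, a lower number a stronger inhibitor), the highest of the three numbers. Compound 2 `Cc1cccc(NS(=O)(=O)c2ccc(N3CCNC3=O)cc2)c1` gives 190 nM, and compound 3 `O=C1NCCN1c1ccc(S(=O)(=O)Nc2ccc(Cl)cc2)cc1` gives 170 nM. The change a 1.8-fold lower number from compound 1 to compound 2 (0.27 log units; within the scatter) stays within the scatter, while a 2.1-fold lower number from compound 1 to compound 3 (0.31 log units; beyond the scatter) is modest but beyond it; the gap a 1.1-fold lower number from compound 2 to compound 3 (0.05 log units; within the scatter) is within the scatter.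

Compound 4 `O=C1NCCN1c1ccc(S(=O)(=O)Nc2cccc(Cl)c2)cc1` has not yet been measured. It differs from compound 1 as follows: 3-chlorophenyl in place of 2-ethylphenyl on a sulfonamide nitrogen. Both measured steps away from compound 1 exchange the 2-ethylphenyl group for another aryl group and lower the number, one by a modest amount. A similar modest lowering is therefore expected here, as a 1.9-fold lower number from compound 1 to compound 4 (0.29 log units; within the scatter). Compound 4 is estimated to give 180 nM, with a likely range from 90 nM to 400 nM.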

Compound 4, half-maximal inhibitory concentration: 79 nM
For compound 4 the middle estimate is 2.3-fold (0.36 log units) above the measured one; the measured number lies below the stated range.
By their numbers in this assay, from the lowest: compound 4; then compounds 3, 2 and 1 (each within the scatter of the next, the first and the last beyond it).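

Where the chlorine sits on the aryl ring matters: 3-chlorophenyl and 4-chlorophenyl have the same atoms, yet exchanging one for the other on the sulfonamide nitrogen gives a change beyond the scatter (a 2.2-fold lower number from compound 3 to compound 4 (0.33 log units; beyond the scatter)). Chloro in place of methyl on an aromatic carbon also gives a real difference (a 2.4-fold lower number from compound 2 to compound 4 (0.38 log units; beyond the scatter)), and the step away from 2-ethylphenyl is the largest seen so far (a 4.4-fold lower number from compound 1 to compound 4 (0.65 log units; beyond the scatter)), making compound 4 the strongest inhibitor of the four. No measurement shown explains why these aryl groups differ.

A 2-chlorophenyl group would show how much of the step from compound 1 comes from the chlorine itself rather than from where it sits. As far as these compounds go, it also remains open whether 3-bromophenyl or 3-methoxyphenyl would match 3-chlorophenyl.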